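Replacing the 2-(hydroxycarbamoyl)ethenyl group of compound 1

The source may hold more compounds than are shown below. What is called first, only, known or untested is meant among the compounds shown, and "the series" means these compounds.

Within the data shown here, in a functional assay on Raji cells (Homo sapiens) for antiproliferative activity, read by MTT assay, with a stated time of 72 h (on this read-out higher numbers stand for weaker inhibition and lower numbers for stronger inhibition), compound 1 `CN(Cc1nc(C2CCN(Cc3ccccc3)CC2)no1)c1ncc(/C=C/C(=O)NO)cn1` gives 547 nM and compound 2 `Cc1ccc(CN2CCC(c3noc(CN(C)c4ncc(/C=C/C(=O)NO)cn4)n3)CC2)cc1` gives 293 nM, so compound 1 stands within the scatter of its only measured neighbour. Compound 3 `CN(Cc1nc(C2CCN(Cc3ccccc3)CC2)no1)c1ncc(C(=O)NO)cn1` differs from compound 1 by one change: hydroxycarbamoyl in place of 2-(hydroxycarbamoyl)ethenyl on an aromatic carbon. It places hydroxycarbamoyl in place of 2-(hydroxycarbamoyl)ethenyl on an aromatic carbon. Among the measured compounds shown here, the only measured step, a 1.9-fold lower number from compound 1 to compound 2 (0.27 log units; within the scatter), is a different change, methyl in place of hydrogen, and gives no guide to this one. No direction is therefore expected in this assay, and no step beyond the scatter. The expected step is a 1.2-fold lower number from compound 1 to compound 3 (0.08 log units; within the scatter). For compound 3 the estimate is 450 nM, with an expected range of 100 nM to 2000 nM.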

Compound 3, half-maximal inhibitory concentration: 27.6 nM
Compound 3: middle estimate off by 16-fold (1.21 log units), on the high side; the measured number lies below the stated range.
By their numbers in this assay, from the lowest: compound 3; then compounds 2 and 1 (each within the scatter of the next).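

Among these compounds, at this position, on an aromatic carbon para to a large group, hydroxycarbamoyl in place of 2-(hydroxycarbamoyl)ethenyl gives the first step beyond the scatter in this assay (a 20-fold lower number from compound 1 to compound 3 (1.30 log units; beyond the scatter)). The earlier methyl change stayed within the scatter, so this position responds far more strongly than that one. Nothing available bears on why this step is so large.

On these data alone, whether the step follows from losing the double bond or from the shorter length stays open; a saturated 2-(hydroxycarbamoyl)ethyl chain would separate the two. Also open, as far as these compounds go, is how a carboxylic acid or a longer chain at this position would read.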